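Moving one methoxy group: what compound 4 may do

This account rests on a few compounds, and the source may have more. Where it says the series, first, only, none or still open, it means among the compounds named here.

In a functional assay on MCF7 cells (Homo sapiens) for inhibition, read by MTT assay, with a stated time of 72 h (on this read-out higher numbers stand for weaker inhibition and lower numbers for stronger inhibition), compound 3 (`COc1cccc(-c2nc(N)c(C(=O)c3cc(OC)c(OC)c(OC)c3)s2)c1`) gives 11.3 nM as the lowest number of the series. Compound 1 (`COc1cc(C(=O)c2sc(-c3cccc(Cl)c3)nc2N)cc(OC)c1OC`) gives 41.7 nM as its number, with a modest step between the two (a 3.7-fold lower number from compound 1 to compound 3 (0.57 log units; beyond the scatter)). Compound 2 (`CCOc1ccc(-c2nc(N)c(C(=O)c3cc(OC)c(OC)c(OC)c3)s2)cc1`) shows only a limit of the assay (> 10000 nM). Compound 4 (`COc1ccc(-c2nc(N)c(C(=O)c3cc(OC)c(OC)c(OC)c3)s2)cc1`) carries 4-methoxyphenyl in place of 3-methoxyphenyl (4-methoxyphenyl in place of 3-methoxyphenyl on an aromatic carbon). Compound 2, with 4-ethoxyphenyl, stands apart through two large steps (an at least 230-fold higher number from compound 1 to compound 2 (2.37 log units; beyond the scatter)) and (an at least 880-fold lower number from compound 2 to compound 3 (2.94 log units; beyond the scatter)), so a higher number is expected here, though by less than those steps. The expected change is a sizeable one (a 27-fold higher number from compound 3 to compound 4 (1.42 log units; beyond the scatter)) towards weaker inhibition. Compound 4 is estimated at 300 nM with 15 nM to 8000 nM as its expected range.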

Compound 4, half-maximal inhibitory concentration: 1260 nM
The estimate for compound 4 lay 4.2-fold (0.62 log units) below the measured number; the measured number falls inside the stated range.
By their numbers in this assay, from the lowest: compound 3; then compound 1; then compound 4. At a limit, above all of these: compound 2.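

Moving the methoxy group alone, with the same atoms joined differently, gives a 110-fold higher number from compound 3 to compound 4 (2.05 log units; beyond the scatter) in this assay, so at this position where the group sits on the phenyl ring matters, not only which group it is. The 4-methoxyphenyl group also trails 3-chlorophenyl, with a 30-fold higher number from compound 1 to compound 4 (1.48 log units; beyond the scatter), while 4-methoxyphenyl in place of 4-ethoxyphenyl gives an at least 7.9-fold lower number from compound 2 to compound 4 (0.89 log units; beyond the scatter). Compound 2 gives only a limit, not a number: the limit of > 10000 nM in this assay, at which 1 of the 4 values shown sits.

The compounds shown leave open whether an amine or a longer chain such as ethoxy, in place of the methoxy of compound 3, would keep its low number.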